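Removing the nitrile from a dimethylphenoxy thiazolidinedione agonist

The source may hold more compounds than are shown below. What is called first, only, known or untested is meant among the compounds shown, and "the series" means these compounds.

Compound 1 `O=C1NC(=O)C(Cc2ccc(Oc3cccc(Cl)c3)cc2)S1`: 318 nM
Compound 2 `Cc1cc(Oc2ccc(CC3SC(=O)NC3=O)cc2)cc(C)c1C#N`: 120 nM
Compound 3 `Cc1cccnc1Oc1ccc(CC2SC(=O)NC2=O)cc1`: 1090 nM

All three share one core and differ only in the aromatic group carried on the oxygen. In a functional assay for agonist activity at Free fatty acid receptor 1 (Homo sapiens), read by FLIPR, in the presence of a further agent that is not named here (on this read-out lower numbers stand for an effect already at smaller amounts and higher numbers for an effect only at larger amounts of compound), compound 2 gives the lowest number of the three, and both compound 1 and compound 3 lie beyond the scatter above it. Compound 4 `Cc1cc(C)cc(Oc2ccc(CC3SC(=O)NC3=O)cc2)c1` differs from compound 2 by hydrogen in place of cyano on an aromatic carbon. Within the data shown here, the only measured step, a 3.4-fold higher number from compound 1 to compound 3 (0.53 log units; beyond the scatter), exchanges one whole aromatic group for another and does not bear directly on removing a cyano group. Compound 1, which also lacks a cyano group, sits higher than compound 2, so a modest rise is expected. For compound 4 the estimate in this assay is 300 nM, between 120 nM and 800 nM. This expected change amounts to a 2.5-fold higher number from compound 2 to compound 4 (0.40 log units; beyond the scatter).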

Compound 4, half-maximal effective concentration: 96 nM
Compound 4: middle estimate off by 3.1-fold (0.49 log units), on the high side, and the stated range ends above it.
By their numbers in this assay, from the lowest: compounds 4 and 2 (each within the scatter of the next); then compound 1; then compound 3.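

In this assay, replacing the cyano group on the aromatic ring with hydrogen, with both methyl groups kept, gives a 1.3-fold lower number from compound 2 to compound 4 (0.10 log units; within the scatter) and stays within the usual scatter. At this place, ortho to two methyl groups and para to a large group, the nitrile is therefore not required for a number of this size. No measurement here bears on why this is so. Going by these compounds, whether an amine, a carboxylic acid or a longer chain at this place would leave the number unchanged remains open. On these data alone, the part played by the two methyl groups also remains open.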